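Working notes: from compound 3 to compound 4

The compounds below may be only part of what the source reports. "The series", "measured", "known", "first", "only" and "open" are said of these compounds alone.

Three compounds have numbers in a functional assay on the whole organism for inhibition, with Chenopodium ficifolium as the target, with a stated time of 72 h, tested at 10 mg/L; a lower number here means less inhibition of growth, a higher number more inhibition of growth at the concentration tested. Compound 1 `COc1cc(Cl)nc2n/c(=N/C(=O)c3c(-c4ccc(Cl)cc4Cl)noc3C)sn12` gives 19.3% in this assay. Compound 2 `COc1cc(C)nc2n/c(=N/C(=O)c3c(-c4ccc(Cl)cc4Cl)noc3C)sn12` gives 45.7%. Compound 3 `Cc1cc(Cl)nc(NC(=S)NC(=O)c2c(-c3ccc(Cl)cc3Cl)noc2C)n1` gives 28.9%. Among the compounds with values here, the only single-change step measured so far is a number 26.4 percentage points higher from compound 1 to compound 2 (beyond the scatter), which came from methyl in place of chloro on an aromatic carbon. Compound 3 stands second highest of the three numbers: its value sits within the scatter of that of compound 1 and beyond the scatter below that of compound 2.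

Compound 4 `COc1cc(OC)nc(NC(=S)NC(=O)c2c(-c3ccc(Cl)cc3Cl)noc2C)n1` has not yet been measured. It differs from compound 3 by 4,6-dimethoxypyrimidin-2-yl in place of 4-chloro-6-methylpyrimidin-2-yl on an amide-type nitrogen. Within the data shown here, the step from compound 1 to compound 2 bears on this only in part: there a chloro gave way to methyl, whereas here both the chloro and the methyl give way to methoxy, and no measured pair shows what methoxy on that ring does in this assay. The expected step is therefore modest and its direction uncertain, a number 6.1 percentage points higher from compound 3 to compound 4 (within the scatter) being the central guess. Compound 4 is expected to give about 35% in this assay, with an estimated range from 15% to 60%.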

Compound 4, percent growth inhibition at one concentration: 30.7%
For compound 4 the middle estimate is 4.3 percentage points above the measured one, and the stated range covers the measured number.
By their numbers in this assay, from the lowest: compounds 1, 3 and 4 (each within the scatter of the next, the first and the last beyond it); then compound 2.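

In this assay, 4,6-dimethoxypyrimidin-2-yl in place of 4-chloro-6-methylpyrimidin-2-yl on the amide-type nitrogen gives a number 1.8 percentage points higher from compound 3 to compound 4 (within the scatter) and leaves the two compounds indistinguishable at the concentration tested. Methoxy on this ring now has a reading of its own, and this place accepts the loss of chloro and methyl together, with a larger group entering, without a step that stands clear of the scatter. The step of a number 26.4 percentage points higher from compound 1 to compound 2 (beyond the scatter) lies beyond the scatter, but it belongs to a different change on a different core and does not carry over to this position, and no supporting measurement is at hand to explain the present result.

Both groups leave at once in this step, so a ring carrying a single methoxy with the chloro or the methyl retained would be needed to show whether the two exchanges offset each other or each does little. On these data alone, whether an amine such as dimethylamino or a longer chain such as ethoxy on this ring would shift the growth inhibition remains open.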